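The source may report more compounds than this note shows. Statements on the series, on what has been measured and on what is new or still open speak of the compounds shown alone.

In an ADME assay on J774 cells (Mus musculus) for cytotoxicity, read by MTT assay, with a stated time of 48 h (on this read-out higher numbers stand for weaker inhibition and lower numbers for stronger inhibition), compound 1 `O=Cc1ccccc1OCc1ccc2no[n+]([O-])c2c1` gives 78 uM. Compound 2 `[O-][n+]1onc2ccc(COc3ccccc3/C=N\NC(=S)Nc3ccccc3)cc21`, tested in this assay as well, gives > 400 uM. That value is a limit of the assay and not a number, so the true position of compound 2 is not known exactly. It stands at the weak end of what has been measured so far: the limit of > 400 uM in this assay, at which 1 of the 2 values shown sits.

Compound 3 `NC(=O)N/N=C\c1ccccc1OCc1ccc2no[n+]([O-])c2c1` has not yet been measured. It differs from compound 2 in one place: a group of 3 heavy atoms (1 carbon, 1 nitrogen, 1 oxygen; no ring) in place of a group of 9 heavy atoms (7 carbon, 1 nitrogen, 1 sulfur; one six-membered aromatic ring of carbon only), on an amine nitrogen. On an amine nitrogen, a small carbamoyl group replaces a larger group that holds a six-membered aromatic ring of carbon only.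

Within the data shown here, no measured pair shows what this exchange does, so the expectation is only rough. Among the measured compounds shown here, it leans on compound 1 at 78 uM, the one true number available for a compound with this core. A moderate move towards stronger inhibition in this assay is expected, and the estimated change is an at least 1.6-fold lower number from compound 2 to compound 3 (0.20 log units; that floor lies within the scatter). The assay may again report only a limit. For compound 3 the estimated value is 250 uM, with an expected range from 100 uM to 600 uM.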

Compound 3, concentration for 50% inhibition: < 100 uM
Compound 3 was reported as a limit; the forecaster's own chance of this, stated with the estimate: 40%; at least 2.5-fold (0.39 log units) between middle value and limit.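

In this assay, the amine nitrogen whose other neighbour is a double-bonded nitrogen proves sensitive to what it carries: a small carbamoyl in place of the larger group that holds a six-membered aromatic ring of carbon only gives an at least 4.0-fold lower number from compound 2 to compound 3 (0.60 log units; beyond the scatter). The earlier compounds shown here offered no pair that could show this, so both the direction of this exchange, towards stronger inhibition of the cells, and the fact that it goes beyond the usual scatter are new. Compound 3 is reported only as a limit of the assay and not as a number, so the step gives a floor and not a true size: the limit of < 100 uM in this assay, at which 1 of the 3 values shown sits.

As far as these compounds go, the step from compound 1 to compound 3 cannot be read, so it stays open how the full side group on the aromatic carbon compares with the smaller group it replaces there. Also open, from the compounds shown here alone, is which part of the exchange matters, the loss of the aromatic ring or the change from sulfur to oxygen, and an acetyl group or a longer chain on the same amine nitrogen could help to separate these two.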